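The source may report more compounds than this note shows. Statements on the series, on what has been measured and on what is new or still open speak of the compounds shown alone.

Measured in a functional assay on the whole organism for antagonist activity, with Mus musculus as the target; a lower number here means that less compound is needed, a higher number that more compound is needed for the effect:
Compound 1 `CC(=O)N(C)C(C)C#CCn1ccnc1`: > 100 mg/kg (a limit of the assay)
Compound 2 `CC(=O)N(C)C(C)C#CCn1ccnc1C`: 0.05 mg/kg

Compound 1 stands only at a limit, > 100 mg/kg, so it has no exact number. Compound 3 `CCOC(=O)N(C)C(C)C#CCn1ccnc1` carries ethoxy in place of methyl on a carbonyl carbon. Among the measured compounds shown here, the only measured step, an at least 2000-fold lower number from compound 1 to compound 2 (3.30 log units; beyond the scatter), is large, but it is methyl in place of hydrogen on an aromatic carbon, so it bears only indirectly. For the measured compounds named here, no measured step involves the carbonyl carbon, so no step beyond the scatter is expected in this assay, though the direction stays open. The expected step is a number no higher from compound 1 to compound 3 (the limit leaves the size open). For compound 3 the estimate is 100 mg/kg, with an expected range of 10 mg/kg to 300 mg/kg.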

Compound 3, dose for half-maximal effect: 54 mg/kg
Compound 3: the middle estimate sits 1.9-fold (0.27 log units) above what was measured, within the range that was stated.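

Replacing methyl with ethoxy on the carbonyl carbon, read as acetyl to ethoxycarbonyl, gives in this assay an at least 1.8-fold lower number from compound 1 to compound 3 (0.26 log units; that floor lies within the scatter). Compound 3 therefore gives an exact number on the shared core, but this floor does not establish a real change at this position. The true size of the step cannot be read because compound 1 stands at a limit: the limit of > 100 mg/kg in this assay, at which 1 of the 3 values shown sits.

The compounds shown leave open how an amine or a longer alkoxy chain on the carbonyl carbon would read. They also leave open whether ethoxycarbonyl and the aromatic methyl of compound 2 would work together.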